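Cytotoxicity notes: aminooxazole series, step from compound 2 to 3

The source may hold more compounds than are shown below. What is called first, only, known or untested is meant among the compounds shown, and "the series" means these compounds.

Measured so far:
compound 1 `N#Cc1ccc(Nc2ncc(Cc3c(F)cccc3F)o2)cc1` gives 7400 nM
compound 2 `OCCc1ccc(Nc2ncc(Cc3c(F)cccc3F)o2)cc1` gives 35000 nM

Both numbers come from an ADME assay on MT2 cells (Homo sapiens) for cytotoxicity, read by MTT assay; on this read-out lower numbers stand for higher toxicity in this test and higher numbers for lower toxicity in this test. Going by the values given here, compound 2 stands highest of the two, with compound 1 as its only neighbour; the sole step, a 4.7-fold higher number from compound 1 to compound 2 (0.67 log units; beyond the scatter), is modest and beyond the scatter. Compound 3 `Fc1cccc(F)c1Cc1cnc(Nc2ccc(Oc3ccncc3)cc2)o1` differs from compound 2 by (pyridin-4-yl)oxy in place of 2-hydroxyethyl on an aromatic carbon. Among the compounds with values here, no measured step shares this change, so the one step on hand bears only loosely. A step of about the size of the measured one, toward lower numbers, is expected: a 1.9-fold lower number from compound 2 to compound 3 (0.29 log units; within the scatter). Compound 3 is therefore estimated at 18000 nM, within 6000 nM to 55000 nM.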

Compound 3, half-maximal cytotoxic concentration: 21000 nM
The estimate for compound 3 lay 1.2-fold (0.07 log units) below the measured number; the range from low to high includes it.
By their numbers in this assay, from the lowest: compound 1; then compounds 3 and 2 (each within the scatter of the next).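

In this assay this aromatic carbon accepts (pyridin-4-yl)oxy, with its six-membered aromatic ring and 0 hydrogen-bond donors, without leaving the scatter of 2-hydroxyethyl (a 1.7-fold lower number from compound 2 to compound 3 (0.22 log units; within the scatter)), so a hydrogen-bond donor here is not required for a number at the level of compound 2. Against cyano the same group gives a step beyond the scatter (a 2.8-fold higher number from compound 1 to compound 3 (0.45 log units; beyond the scatter)), which leaves compound 1 alone at the low end of the three. No measurement available here accounts for either step.

On these data alone, whether a primary amine or a carboxylic acid on this carbon would stay with compounds 2 and 3 or fall toward compound 1 remains open. Also open, as far as these compounds go, is how a longer chain ending in hydroxyl would read.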